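Thiophen-2-yl in place of 4-methoxyphenyl on compound 2

The source may hold more compounds than are shown below. What is called first, only, known or untested is meant among the compounds shown, and "the series" means these compounds.

Compound 2 (`COc1ccc(-c2nc3ccccn3c2/C=C/C(=O)c2cc(OC)c(OC)c(OC)c2)cc1`) gives 3900 nM in a functional assay on 786-0 cells (Homo sapiens) for inhibition, read by sulforhodamine B assay, with a stated time of 48 h (a higher number here means a weaker inhibitor of growth, a lower number a stronger inhibitor of growth), and does not stand apart from the other measured compounds. Compound 3 (`COc1ccc(-c2nc3ccccn3c2/C=C/C(=O)c2cc(OC)c(OC)c(OC)c2)cc1OC`) gives 3740 nM and compound 1 (`COc1cc(C(=O)/C=C/c2c(-c3ccc(F)cc3)nc3ncccn23)cc(OC)c1OC`) gives 2760 nM in this assay and all three values lie within the scatter of one another.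

Compound 4 (`COc1cc(C(=O)/C=C/c2c(-c3cccs3)nc3ccccn23)cc(OC)c1OC`) has not yet been measured. It departs from compound 2 by a single change, thiophen-2-yl in place of 4-methoxyphenyl on an aromatic carbon.

Within the data shown here, the only measured step on this group is a 1.0-fold lower number from compound 2 to compound 3 (0.02 log units; within the scatter) for methoxy in place of hydrogen on an aromatic carbon, and it stays within the scatter. Among the measured compounds shown here, compound 1 differs from compound 2 in more than one place, so it offers no clean step, and no measured compound carries thiophen-2-yl. The evidence for this change is therefore thin, and no shift beyond the scatter is expected, though the range is kept wide.

The estimated change is a 1.2-fold lower number from compound 2 to compound 4 (0.09 log units; within the scatter) and this expected difference would remain within the scatter. Compound 4 is expected at 3200 nM with an estimated range from 1300 nM to 8000 nM in this assay when it is measured.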

Compound 4, concentration for 50% growth inhibition: 2310 nM
The estimate for compound 4 lay 1.4-fold (0.14 log units) above the measured number; the range from low to high includes it.
By their numbers in this assay, from the lowest: compounds 4, 1, 3 and 2 (each within the scatter of the next).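

Swapping the whole aryl ring at this position, on an aromatic carbon of the five-membered ring with 2 nitrogen, moves the number in this assay no further than the scatter, whether thiophen-2-yl replaces 4-methoxyphenyl (a 1.7-fold lower number from compound 2 to compound 4 (0.23 log units; within the scatter)) or 3,4-dimethoxyphenyl (a 1.6-fold lower number from compound 3 to compound 4 (0.21 log units; within the scatter)). The earlier clean step changed only a methoxy on the phenyl ring, whereas these two steps show that a six-membered aromatic ring of carbon only, with 8 or more heavy atoms in the group, can give way to a five-membered aromatic ring with a sulfur and 5 heavy atoms and still leave all the numbers within the scatter of one another. No other measurement bears on this result, and nothing shown accounts for it.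

No step among these compounds lies beyond the scatter, so it remains open what size of change this position can show at all. Whether an amine, a carboxylic acid, a longer alkyl chain or a thiophen-3-yl at this place would shift the number beyond the scatter is not answered by the compounds shown.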